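This account rests on a few compounds, and the source may have more. Where it says the series, first, only, none or still open, it means among the compounds named here.

Measured so far:
Compound 1, `N#CCN(Cc1ccccc1)Cc1cnc2ccccc2c1`: in an assay on HEK293 cells for binding affinity to Substance-K receptor (Rattus norvegicus), read by FRET, tested at 10 uM (a higher number here means more inhibition at the concentration tested (going by the name of the read-out), a lower number less inhibition), compound 1 gives 21%.
Compound 2, `N#CCCCN(Cc1ccccc1)Cc1ccc2ccccc2c1`: in this assay compound 2 gives 0%.

For the measured compounds named here, compound 2 stands at the lowest of the two numbers so far. Going by the values given here, the only comparison available is with compound 1, whose reading in this assay is the higher one, and the gap between the two readings is beyond the usual scatter of this measurement. Among the compounds with values here, no step between compounds that differ in one place is available within the measured pair, so nothing about the effect of a single change has been seen directly.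

The next compound, compound 3 `O=C(CN(Cc1ccccc1)Cc1ccc2ccccc2c1)N1CCCCC1`, is made from compound 2 by one change: (piperidin-1-yl)carbonyl in place of 2-cyanoethyl on a saturated chain carbon bound to an amine nitrogen. Within the data shown here, nothing measured so far bears on this particular exchange, and compound 2 itself sits at the floor of the read-out, so there is no room for a decrease to show. The expectation is for a small rise at most, a step of a number 8 percentage points higher from compound 2 to compound 3 (within the scatter) that may well stay within the scatter.

Compound 3 is therefore estimated at 8% in this assay, with a plausible range from -5% to 25%.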

Compound 3, a percentage reported as inhibition, at one concentration (the size of the read-out at that concentration, not a potency): 0%
Compound 3: middle estimate off by 8 percentage points, on the high side; the range from low to high includes it.
By their numbers in this assay, from the lowest: compounds 2 and 3 (each within the scatter of the next); then compound 1.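

In this assay, for the compounds shown here, the first single exchange, (piperidin-1-yl)carbonyl in place of 2-cyanoethyl on a saturated chain carbon bound to an amine nitrogen, gives no change at the digits printed from compound 2 to compound 3 (within the scatter), so this position accepts a larger group with a six-membered non-aromatic ring without any visible difference in the read-out. Because both compounds lie at the bottom of the read-out, this step cannot show a loss, and it does not show that the two groups are equivalent at this position; it shows only that neither gives a detectable reading on this core at the single concentration tested. No supporting measurement bears on why the reading stays where it does.

Still open, on these data alone, is whether another group at this place, such as a primary amine, a carboxylic acid or a longer chain, would lift the reading on this core into a measurable range. Also open, as far as these compounds go, is how (piperidin-1-yl)carbonyl would behave on the core of compound 1 , which gives 21% and so leaves room for a decrease to show.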